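Fluoro in place of hydrogen on the pyridin-3-yl group

The compounds below may be only part of what the source reports. "The series", "measured", "known", "first", "only" and "open" are said of these compounds alone.

Compound 1 `CC1CCN(C2CCN(S(=O)(=O)c3cccnc3)CC2)CC1` is the starting point for this step, and its position in an ADME assay on HCT-116 cells (Homo sapiens) for cytotoxicity, read by CellTiter-Glo, with a stated time of 72 h (on this read-out higher numbers stand for weaker inhibition and lower numbers for stronger inhibition), is known only as a limit. In that assay compound 1 gives > 10000 nM, which is a limit of the assay and not a number. Compound 2 `Cc1ccc(C2CCN(S(=O)(=O)c3c(C)cc(C)cc3C)CC2)cc1` also gives only a limit, > 5000 nM. Within the data shown here, these two limits set no order between compound 1 and compound 2, and no measured pair shows the size of a single change.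

Compound 3 `CC1CCN(C2CCN(S(=O)(=O)c3cccnc3F)CC2)CC1` keeps the core of compound 1 and carries one change, (fluoro in place of hydrogen on an aromatic carbon), taking pyridin-3-yl to 2-fluoropyridin-3-yl. The only basis for an expectation is the limit of compound 1, > 10000 nM. In this assay the step of a number no higher from compound 1 to compound 3 (the limit leaves the size open) is expected to stay within the scatter, with no clear direction. The assay will most likely report only a limit again. For compound 3 the estimated value is 10000 nM, with an expected range from 4000 nM to 20000 nM.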

Compound 3, half-maximal inhibitory concentration: > 10000 nM
Compound 3 ended at the assay's limit; the forecaster's own chance of this, stated with the estimate: 85%; the middle value sits exactly at the limit.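

In this assay compound 3 gives > 10000 nM, which is a limit of the assay and not a number. Among these compounds, compound 1 gives > 10000 nM, also a limit, so no step between compound 1 and compound 3 can be read. The compounds shown leave open whether fluoro in place of hydrogen changes the value in this assay at all.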